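The compounds below may be only part of what the source reports. "The series", "measured", "known", "first", "only" and "open" are said of these compounds alone.

Working notes on the series. For the measured compounds named here, in an assay on isolated protein (strain Balb/c) for inhibition of Polyunsaturated fatty acid 5-lipoxygenase (Mus musculus), read by immunoassay, with a stated time of 20 min (on this read-out lower numbers stand for stronger inhibition and higher numbers for weaker inhibition), compound 1 `c1ccc(Nc2nc3ccccc3o2)cc1` gives 8910 nM, and compound 2 `CCc1ccc(Nc2nc3ccccc3o2)cc1` gives 1210 nM; the single measured step is a 7.4-fold lower number from compound 1 to compound 2 (0.87 log units; beyond the scatter). Compound 2 thus holds the lowest number of the two. Compound 3 `CCc1ccc(Nc2nc3cc([N+](=O)[O-])ccc3o2)cc1` differs from compound 2 by nitro in place of hydrogen on an aromatic carbon. Going by the values given here, no measured step touches this group or this place, so the only step available offers no guide, and for compound 3 no step beyond the scatter is expected in this assay. For compound 3 the estimated value is 1200 nM, with a range from 400 nM to 3600 nM, which means an expected step of a 1.0-fold lower number from compound 2 to compound 3 (0.00 log units; within the scatter).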

Compound 3, half-maximal inhibitory concentration: 23900 nM
Compound 3: the middle estimate sits 20-fold (1.30 log units) below what was measured; measured number above the stated range.
By their numbers in this assay, from the lowest: compound 2; then compound 1; then compound 3.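

In this assay, the six-membered aromatic ring of carbon only, part of the fused system, proves sensitive to change: nitro in place of hydrogen gives a 20-fold higher number from compound 2 to compound 3 (1.30 log units; beyond the scatter). For the compounds shown here, the only earlier step, a 7.4-fold lower number from compound 1 to compound 2 (0.87 log units; beyond the scatter), came from ethyl at a different place and ran the opposite way, so a change at this carbon can raise the number sharply. Nothing at hand bears on the reason for this step.

From the compounds shown here alone, whether the rise is specific to nitro remains open, since an amine or a methyl group at this carbon would test that. Going by these compounds, the other carbons of this ring also remain open.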